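Swapping methyl for fluoro beside the phenol

A few compounds are considered here, and "the series" means these few. Any claim that something is new, unique, unknown or untested is made for them only; others in the source may bear on it.

Measured so far:
- compound 1 `CC(=O)/C=C/c1cccc(C)c1O`: 3630 nM
- compound 2 `CC(=O)/C=C/c1cccc(C(C)(C)C)c1O`: 2190 nM

Both were tested in a functional assay for inhibition, with Oryctolagus cuniculus as the target; a lower number here means a stronger inhibitor, a higher number a weaker inhibitor. Compound 1 gives the highest of the two numbers, and its nearest neighbour is compound 2, with a 1.7-fold lower number from compound 1 to compound 2 (0.22 log units; within the scatter). Compound 3 `CC(=O)/C=C/c1cccc(F)c1O` differs from compound 1 in one place: fluoro in place of methyl on an aromatic carbon. Within the data shown here, the only comparison available at this position is that step, which stayed within the scatter, and no measured compound carries fluoro here. The expected change is therefore small, a 1.1-fold higher number from compound 1 to compound 3 (0.04 log units; within the scatter). Compound 3 is estimated at 4000 nM, between 1500 nM and 11000 nM.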

Compound 3, half-maximal inhibitory concentration: 51200 nM
Compound 3: middle estimate off by 13-fold (1.11 log units), on the low side, outside the stated range (above it).
By their numbers in this assay, from the lowest: compounds 2 and 1 (each within the scatter of the next); then compound 3.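

In this assay this position, ortho to a hydroxy group, proves sensitive to the group it carries: fluoro gives a 14-fold higher number from compound 1 to compound 3 (1.15 log units; beyond the scatter) and a 23-fold higher number from compound 2 to compound 3 (1.37 log units; beyond the scatter) in the same series. Methyl and fluoro each have 1 heavy atom, yet they lie far apart, whereas methyl and tert-butyl stay within the scatter of each other. Nothing available here bears on why fluoro stands apart.

As far as these compounds go, it remains open whether chloro, methoxy or an amine at this position would sit with fluoro or with the two alkyl groups.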